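Taking the Fluoro Group off Compound 3

The source may report more compounds than this note shows. Statements on the series, on what has been measured and on what is new or still open speak of the compounds shown alone.

In a functional assay on MCF7 cells (Homo sapiens) for antiproliferative activity, with a stated time of 72 h (on this read-out lower numbers stand for stronger inhibition and higher numbers for weaker inhibition), compound 3 `O=C(COc1ccc(CNC2CC=C(c3c[nH]c4ccc(F)cc34)CC2)c(F)c1)NO` gives 1420 nM. This lies within the scatter of compound 2 `Cc1[nH]c2ccccc2c1C1=CCN(Cc2ccc(OCC(=O)NO)cc2)CC1` at 1590 nM and of compound 1 `O=C(COc1ccc(CNC2CC=C(c3c[nH]c4cccc(F)c34)CC2)c(F)c1)NO` at 915 nM. Compound 4 `O=C(COc1ccc(CNC2CC=C(c3c[nH]c4ccccc34)CC2)c(F)c1)NO` carries hydrogen in place of fluoro on an aromatic carbon of compound 3: hydrogen in place of fluoro on an aromatic carbon. Going by the values given here, one measured step bears on this, 5-fluoro-1H-indol-3-yl in place of 4-fluoro-1H-indol-3-yl, and it stays small at a 1.6-fold higher number from compound 1 to compound 3 (0.19 log units; within the scatter). It moves the fluoro rather than removing it, so the evidence is indirect, and no change beyond the scatter is expected in this assay. The expected step is a 1.2-fold lower number from compound 3 to compound 4 (0.07 log units; within the scatter). The estimate for compound 4 is 1200 nM, with an expected range from 520 nM to 2700 nM.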

Compound 4, half-maximal inhibitory concentration: 1170 nM
The estimate for compound 4 lay 1.0-fold (0.01 log units) above the measured number; low and high end bracket the measured number.
By their numbers in this assay, from the lowest: compounds 1, 4, 3 and 2 (each within the scatter of the next).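

Taking the fluoro off outright, rather than moving it, is now measured directly: a 1.2-fold lower number from compound 3 to compound 4 (0.08 log units; within the scatter) shows that 1H-indol-3-yl and 5-fluoro-1H-indol-3-yl cannot be told apart in this assay. The second comparison, a 1.3-fold higher number from compound 1 to compound 4 (0.11 log units; within the scatter), does the same for the 4-fluoro-1H-indol-3-yl group, so neither fluoro placement separates from hydrogen in these compounds. Nothing available gives a reason for this. Still open, from the compounds shown here alone, is whether a larger group on this aromatic carbon, such as methoxy or an amine, would shift the number beyond the scatter.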